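A few compounds are considered here, and "the series" means these few. Any claim that something is new, unique, unknown or untested is made for them only; others in the source may bear on it.

Measured compounds:
compound 1, `CNc1nc(Nc2ccc(C)c([N+](=O)[O-])c2)ncc1C(=O)Nc1cc(NC(=O)c2cccc(C(F)(F)F)c2)ccc1C` — 52 nM
compound 2, `CNc1nc(Nc2ccc(C)c(N)c2)ncc1C(=O)Nc1cc(NC(=O)c2cccc(C(F)(F)F)c2)ccc1C` — 14 nM

Both were tested in a functional assay on K562 cells (Homo sapiens) for antiproliferative activity, read by CellTiter-Glo and CCK-8 assay, with a stated time of 72 h; on this read-out higher numbers stand for weaker inhibition of growth and lower numbers for stronger inhibition of growth. Compound 1 gives 52 nM, the higher of the two numbers. Compound 2 gives 14 nM. Going by the values given here, the only measured step, a 3.7-fold lower number from compound 1 to compound 2 (0.57 log units; beyond the scatter), alters a group on the shared core and leaves the carbonyl end of the molecule untouched.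

Compound 3, `CNc1nc(Nc2ccc(C)c([N+](=O)[O-])c2)ncc1C(=O)Nc1cc(NC(=O)c2ccc(OC)cc2)ccc1C`, keeps the nitro group of compound 1 and differs from it only at that carbonyl end: 4-methoxyphenyl in place of 3-(trifluoromethyl)phenyl on a carbonyl carbon. Among the compounds with values here, no measured step touches this position, so the step from compound 1 to compound 2 bears on it only in showing that a single change elsewhere moved the number by a modest amount. With nothing to fix the direction, the estimate for compound 3 is placed a little above the number for compound 1, as a 2.9-fold higher number from compound 1 to compound 3 (0.46 log units; beyond the scatter), with a range wide enough to include no change beyond the scatter. Compound 3 is therefore expected to give 150 nM, between 30 nM and 1000 nM.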

Compound 3, concentration for 50% growth inhibition: 1530 nM
Estimate against measurement, compound 3: 10-fold (1.01 log units) below, and the stated range ends below it.
By their numbers in this assay, from the lowest: compound 2; then compound 1; then compound 3.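

In this assay the carbonyl end of the molecule proves to be a sensitive position: 4-methoxyphenyl in place of 3-(trifluoromethyl)phenyl gives a 29-fold higher number from compound 1 to compound 3 (1.47 log units; beyond the scatter) and so weakens growth inhibition far more than the change at the nitro group strengthens it, which gives a 3.7-fold lower number from compound 1 to compound 2 (0.57 log units; beyond the scatter) on the other side of the molecule. Going by these compounds alone, until this result, only that nitro position had been seen to move the number, and only modestly. The group on the carbonyl carbon now appears to weigh more heavily on activity than that one, although this rests on a single pair of compounds. Nothing available explains the loss of activity.

This one swap removes trifluoromethyl and brings in methoxy together, so the compounds shown cannot tell whether losing the first or gaining the second accounts for the shift, and a plain phenyl group on the same carbonyl carbon would help to separate the two. Going by these compounds, it also stays open whether the swap would cost as much on compound 2, with its amino group, as it does on compound 1, with its nitro group.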